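The source may report more compounds than this note shows. Statements on the series, on what has been measured and on what is new or still open speak of the compounds shown alone.

Working notes on the series. Among the measured compounds shown here, in a functional assay on HeLa cells (Homo sapiens) for inhibition, read by MTT assay, with a stated time of 72 h (a higher number here means a weaker inhibitor, a lower number a stronger inhibitor), compound 1 (`Clc1ccc(-c2nnc(SCCCN3CCN(c4nc5ccccc5s4)CC3)o2)cc1`) gives 177000 nM and compound 2 (`CC(C)(C)Oc1ccc(-c2nnc(SCCCN3CCN(c4nc5ccccc5s4)CC3)o2)cc1`) gives 217000 nM, so compound 2 cannot be told apart from the only other measured compound. Compound 3 (`Oc1ccc(-c2nnc(SCCCN3CCN(c4nc5ccccc5s4)CC3)o2)cc1`) has not yet been measured in this assay. Its change from compound 2 is hydrogen in place of tert-butyl on an oxygen on an aromatic ring, which is hydrogen in place of tert-butyl on an oxygen on an aromatic ring, or tert-butoxy to hydroxy. For the measured compounds named here, one measured step bears on this: tert-butoxy in place of chloro on an aromatic carbon gave a 1.2-fold higher number from compound 1 to compound 2 (0.09 log units; within the scatter). Going by the values given here, no hydroxy compound has been measured, so the direction stays open, and no step beyond the scatter is expected in this assay. The expected step is a 1.3-fold lower number from compound 2 to compound 3 (0.11 log units; within the scatter). The estimated value for compound 3 is 170000 nM, with an expected range of 70000 nM to 350000 nM.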

Compound 3, half-maximal inhibitory concentration: 139000 nM
The estimate for compound 3 lay 1.2-fold (0.09 log units) above the measured number; the measured number falls inside the stated range.
By their numbers in this assay, from the lowest: compounds 3, 1 and 2 (each within the scatter of the next).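

In this assay, replacing tert-butyl with hydrogen on the oxygen on the aromatic ring gives a 1.6-fold lower number from compound 2 to compound 3 (0.19 log units; within the scatter), and hydroxy in place of chloro on the aromatic carbon gives a 1.3-fold lower number from compound 1 to compound 3 (0.10 log units; within the scatter). The hydroxy compound therefore adds a third group at this position, and with chloro and tert-butoxy it still yields no step beyond the scatter, even with the four carbons of the tert-butyl gone. No supporting evidence bears on this result, so the numbers alone describe it.

The compounds shown leave open whether an amine or a carboxylic acid at this position would produce a step beyond the scatter. They also leave open whether a change elsewhere, such as a longer chain in place of the one in the shared core, would move the number at all.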